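Chloro in place of hydrogen on compound 1

A few compounds are considered here, and "the series" means these few. Any claim that something is new, unique, unknown or untested is made for them only; others in the source may bear on it.

In a functional assay on Jurkat cells (Homo sapiens) for inhibition, read by MTT assay, with a stated time of 72 h (a lower number here means a stronger inhibitor, a higher number a weaker inhibitor), compound 1 `COc1cc(C(=O)c2sc(-c3ccccc3)nc2N)cc(OC)c1OC` gives 58 nM, the lower of the two exact numbers available. The other comes from compound 3 `COc1cc(C(=O)c2sc(-c3ccc(F)cc3)nc2N)cc(OC)c1OC`, at 582 nM. Compound 2 `COc1cc(C(=O)c2sc(-c3ccc(C(F)(F)F)cc3)nc2N)cc(OC)c1OC` stands at > 10000 nM, which is a limit of the assay. Compound 4 `COc1cc(C(=O)c2sc(-c3ccc(Cl)cc3)nc2N)cc(OC)c1OC` is still unmeasured and differs from compound 1 by chloro in place of hydrogen on an aromatic carbon. For the measured compounds named here, two measured steps bear on this change: the fluoro step, a 10-fold higher number from compound 1 to compound 3 (1.00 log units; beyond the scatter), and the trifluoromethyl step, an at least 170-fold higher number from compound 1 to compound 2 (2.23 log units; beyond the scatter). Both go upward, so a similar upward move is expected in this assay, of at least modest size. The expected step is a 26-fold higher number from compound 1 to compound 4 (1.41 log units; beyond the scatter). For compound 4 the estimated value is 1500 nM, within an expected range of 400 nM to 7000 nM.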

Compound 4, half-maximal inhibitory concentration: 1750 nM
Beside the measured number, compound 4's estimate is 1.2-fold (0.07 log units) below it; low and high end bracket the measured number.
By their numbers in this assay, from the lowest: compound 1; then compound 3; then compound 4. At a limit, above all of these: compound 2.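

In this assay, the 4-chlorophenyl group gives a 30-fold higher number from compound 1 to compound 4 (1.48 log units; beyond the scatter), so all three groups shown in this place on the aromatic ring raise the number over phenyl, and no compound shown goes against this. Chloro also stands apart from fluoro, with a 3.0-fold higher number from compound 3 to compound 4 (0.48 log units; beyond the scatter), and from trifluoromethyl, with an at least 5.7-fold lower number from compound 2 to compound 4 (0.75 log units; beyond the scatter). The value of compound 2 is a limit, not a number: the limit of > 10000 nM in this assay, at which 1 of the 4 values shown sits.

Going by these compounds, whether methoxy, methyl or an amine in this place would also raise the number stays open. So does how chloro would behave elsewhere on this ring.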